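Replacing the Pyridinylsulfanyl Arm with Cyclopentyloxy

A few compounds are considered here, and "the series" means these few. Any claim that something is new, unique, unknown or untested is made for them only; others in the source may bear on it.

Compound 1 `Cc1cc(Br)c(S(C)(=O)=O)cc1C(=O)N=C(N)N` and compound 2 `Cc1cc(Sc2ccncc2)c(S(C)(=O)=O)cc1C(=O)N=C(N)N` share the same core and differ only at one aromatic carbon. In a functional assay for inhibition of sodium/hydrogen exchanger (Oryctolagus cuniculus) (a higher number here means a weaker inhibitor, a lower number a stronger inhibitor), compound 1 gives 12 nM, and compound 2 gives 13 nM. The change from bromo to (pyridin-4-yl)sulfanyl produced a 1.1-fold higher number from compound 1 to compound 2 (0.03 log units; within the scatter). Among the measured compounds shown here, compound 2 therefore carries the highest of the two numbers so far, but its only neighbour, compound 1, sits within the scatter of it, so no order between the two can be claimed.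

Compound 3 `Cc1cc(OC2CCCC2)c(S(C)(=O)=O)cc1C(=O)N=C(N)N` has not yet been measured in this assay. It differs from compound 2 in one place: cyclopentyloxy in place of (pyridin-4-yl)sulfanyl on an aromatic carbon. For the measured compounds named here, the single measured step that bears on this position, the one from compound 1 to compound 2, was within the scatter, and it shows that two quite different groups on that carbon gave near-identical numbers. On that basis no step beyond the scatter is expected in this assay for compound 3, in either direction, so a 1.2-fold higher number from compound 2 to compound 3 (0.06 log units; within the scatter) is the expected change. Compound 3 is thus estimated at 15 nM, with a range from 5 nM to 50 nM.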

Compound 3, half-maximal inhibitory concentration: 27 nM
Estimate against measurement, compound 3: 1.8-fold (0.26 log units) below; measured number inside the range.
By their numbers in this assay, from the lowest: compounds 1 and 2 (each within the scatter of the next); then compound 3.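

In this assay, the aromatic carbon ortho to the methylsulfonyl group proves not to be indifferent to its substituent: bromo and (pyridin-4-yl)sulfanyl could not be told apart there, but cyclopentyloxy gives a 2.1-fold higher number from compound 2 to compound 3 (0.32 log units; beyond the scatter) and a 2.3-fold higher number from compound 1 to compound 3 (0.35 log units; beyond the scatter) against the two earlier groups. Both steps are modest, so this change weakens inhibition measurably but only slightly, and compound 3 is the weakest inhibitor of the three shown. Nothing available explains why cyclopentyloxy behaves differently from the other two groups.

The compounds shown leave open whether the step follows the oxygen link or the five-membered non-aromatic ring, as the two enter together in one change; a phenoxy or a cyclopentylsulfanyl group on the same carbon would separate them. Also open, as far as these compounds go, is how an amine or a longer alkoxy chain on this carbon would read in this assay, and so whether the step seen with cyclopentyloxy extends to other groups joined through a non-sulfur atom.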